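The source may report more compounds than this note shows. Statements on the series, on what has been measured and on what is new or still open speak of the compounds shown alone.

Series notes, measured in a functional assay on A-375 cells (Homo sapiens) for antiproliferative activity, read by sulforhodamine B assay, with a stated time of 48 h; on this read-out lower numbers stand for stronger inhibition and higher numbers for weaker inhibition:

- compound 1 `CCCCCCCCCCCCCCCCNC(=O)c1c[nH]c(-c2ccccc2)n1`: 16500 nM
- compound 2 `CCCCCCCCCCCCCCNC(=O)[C@@H]1CNC(c2ccccc2)=N1`: 7100 nM

Compound 2 has the lower of the two numbers in this assay, at 7100 nM. Its gap to compound 1, at 16500 nM, lies beyond the usual scatter, but two values make a very short scale and show no trend.

The next compound is compound 3 `CCCCCCCCCCCCCCCCCCNC(=O)[C@@H]1CNC(c2ccccc2)=N1`, which is related to compound 2 by one structural change: butyl in place of hydrogen on a saturated chain carbon, ten or more bonds along the chain from an amide-type nitrogen. The change is butyl in place of hydrogen on a saturated chain carbon, ten or more bonds along the chain from an amide-type nitrogen, so it extends the chain and leaves the shared core untouched.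

Among the compounds with values here, the series has no measured pair that differs in one place, so no measured step shows how chain extension moves the number in this assay. The expectation therefore starts from compound 2 at 7100 nM, with a wide margin on both sides. The expected change, a 1.2-fold lower number from compound 2 to compound 3 (0.07 log units; within the scatter), is estimated to stay within the scatter, with no clear direction. The estimate for compound 3 is 6000 nM, with an expected range of 2000 nM to 18000 nM.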

Compound 3, half-maximal inhibitory concentration: 54300 nM
Compound 3: middle estimate off by 9.1-fold (0.96 log units), on the low side; measured number above the stated range.
By their numbers in this assay, from the lowest: compound 2; then compound 1; then compound 3.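

In this assay the long chain on the amide-type nitrogen proves to be a place where the number responds: butyl in place of hydrogen on a saturated chain carbon, ten or more bonds along the chain from an amide-type nitrogen, gives a 7.6-fold higher number from compound 2 to compound 3 (0.88 log units; beyond the scatter) and so lies beyond the scatter. Within the data shown here, this is the first one-place step, and it shows that extending the chain with the shared core untouched weakens inhibition in this assay rather than leaving the number flat. No supporting data are available to account for this loss, so it stands as an observation on a single pair.

With one readable step, the compounds shown leave open whether the number rises steadily with chain length or changes abruptly somewhere between compound 2 and compound 3, and an ethyl group at the same chain carbon or a still longer chain would help separate these two readings. They also leave open how the number would move with an amine or a carboxylic acid in place of butyl at that chain carbon.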